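A few compounds are considered here, and "the series" means these few. Any claim that something is new, unique, unknown or untested is made for them only; others in the source may bear on it.

Measured so far:
Compound 1, `COc1ccc2c(=O)c(/C=C/C(=O)Nc3ccccc3Cl)coc2c1`, gives 29900 nM.
Compound 2, `COc1ccc2c(=O)c(/C=C/C(=O)Nc3ccccc3OC)coc2c1`, gives > 100000 nM, which is a limit of the assay rather than a number.
Compound 3, `COc1ccc2c(=O)c(/C=C/C(=O)NCc3ccc(F)cc3F)coc2c1`, gives 13300 nM.

All three values come from a functional assay on A549 cells (Homo sapiens) for inhibition, read by MTT assay, with a stated time of 48 h; on this read-out lower numbers stand for stronger inhibition and higher numbers for weaker inhibition. Compound 3 holds the lowest of the two numbers; its nearest neighbour is compound 1, and the step of a 2.2-fold lower number from compound 1 to compound 3 (0.35 log units; beyond the scatter) lies beyond the scatter. Compound 2 sits at the limit (the limit of > 100000 nM in this assay, at which 1 of the 3 values shown sits), so the step of an at least 7.5-fold lower number from compound 2 to compound 3 (0.87 log units; beyond the scatter) can only be given as a bound. Compound 4, `COc1ccc2c(=O)c(/C=C/C(=O)Nc3ccc(C)cc3)coc2c1`, is not yet measured. It differs from compound 3 in one place: 4-methylphenyl in place of 2,4-difluorobenzyl on an amide-type nitrogen. For the measured compounds named here, two measured steps bear on this change, each exchanging the 2,4-difluorobenzyl on the amide-type nitrogen for a substituted phenyl, as compound 4 does with 4-methylphenyl: a 2.2-fold lower number from compound 1 to compound 3 (0.35 log units; beyond the scatter) and an at least 7.5-fold lower number from compound 2 to compound 3 (0.87 log units; beyond the scatter), both read in reverse. Both phenyl amides gave higher numbers than compound 3, though neither carries 4-methylphenyl, so the size of the step is uncertain. A higher number is therefore expected for compound 4, about a 3.4-fold higher number from compound 3 to compound 4 (0.53 log units; beyond the scatter). Compound 4 is estimated at 45000 nM in this assay, with a range from 13000 nM to 150000 nM.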

Compound 4, half-maximal inhibitory concentration: 17500 nM
Compound 4: middle estimate off by 2.6-fold (0.41 log units), on the high side; low and high end bracket the measured number.
By their numbers in this assay, from the lowest: compounds 3, 4 and 1 (each within the scatter of the next, the first and the last beyond it). At a limit, above all of these: compound 2.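

In this assay, a 1.3-fold higher number from compound 3 to compound 4 (0.12 log units; within the scatter) shows that a phenyl group on the amide-type nitrogen does not by itself set a compound apart from the 2,4-difluorobenzyl compound, as the two earlier phenyl amides could have suggested. The 4-methylphenyl compound also cannot be told apart from the 2-chlorophenyl compound, with a 1.7-fold lower number from compound 1 to compound 4 (0.23 log units; within the scatter), even though the step between those two earlier compounds and compound 3 lies beyond the scatter for that pair alone. Among the groups compared here, only the 2-methoxyphenyl group stands clearly apart, with an at least 5.7-fold lower number from compound 2 to compound 4 (0.75 log units; beyond the scatter), and the size of this step is a bound set by a limit of the assay rather than by a number: the limit of > 100000 nM in this assay, at which 1 of the 4 values shown sits.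

The compounds shown leave open whether the distance of the 2-methoxyphenyl compound from the others belongs to the methoxy group itself or to where it sits on the ring, which a 4-methoxyphenyl or a 4-chlorophenyl group on the same nitrogen would address. They also leave open how an unsubstituted phenyl, a plain benzyl or an open alkyl chain on that nitrogen would read out in this assay.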